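The source may report more compounds than this note shows. Statements on the series, on what has been measured and on what is new or still open speak of the compounds shown alone.

Compound 1 `COc1cc(-c2nccn2C(C)C)cc(OC)c1OC`: > 100000 nM (a limit of the assay, not a number)
Compound 2 `COc1cc(-c2nccn2-c2ccc(C)cc2)cc(OC)c1OC`: 1600 nM
Compound 3 `COc1cc(-c2nccn2-c2cccc(C)c2)cc(OC)c1OC`: 14600 nM

In a functional assay on HT-29 cells (Homo sapiens) for antiproliferative activity, read by MTT assay, with a stated time of 72 h (a lower number here means a stronger inhibitor, a higher number a weaker inhibitor), compound 3 gives 14600 nM, the higher of the two true numbers, so it is the weaker of the two compounds with a measured number. Its nearest neighbour is compound 2, through a 9.1-fold higher number from compound 2 to compound 3 (0.96 log units; beyond the scatter). Compound 4 `COc1cccc(-n2ccnc2-c2cc(OC)c(OC)c(OC)c2)c1` carries methoxy in place of methyl on an aromatic carbon. Going by the values given here, no measured step makes this swap. Among the compounds with values here, the closest guides are that modest step and an at least 6.8-fold lower number from compound 1 to compound 3 (0.83 log units; beyond the scatter), which show only that changes to this group can shift the number. They give no direction, so a small step is expected, no larger than the modest one. The expected step is a 1.2-fold lower number from compound 3 to compound 4 (0.09 log units; within the scatter). For compound 4 the estimate is 12000 nM, with an expected range of 3000 nM to 50000 nM.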

Compound 4, half-maximal inhibitory concentration: 18900 nM
Compound 4: the middle estimate sits 1.6-fold (0.20 log units) below what was measured, and the stated range covers the measured number.
By their numbers in this assay, from the lowest: compound 2; then compounds 3 and 4 (each within the scatter of the next). At a limit, above all of these: compound 1.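

In this assay, exchanging methyl for methoxy on this aromatic carbon, meta to a large group, makes no readable difference, with a 1.3-fold higher number from compound 3 to compound 4 (0.11 log units; within the scatter). So 3-methoxyphenyl stays well apart from the 4-methylphenyl of compound 2, with a 12-fold higher number from compound 2 to compound 4 (1.07 log units; beyond the scatter), and also from the isopropyl of compound 1, with an at least 5.2-fold lower number from compound 1 to compound 4 (0.72 log units; beyond the scatter). Compound 1 stands at a limit, not a number: the limit of > 100000 nM in this assay, at which 1 of the 4 values shown sits.

As far as these compounds go, whether methoxy would match compound 2 if it stood where the methyl of 4-methylphenyl stands remains open. So does the effect of an amine or a carboxylic acid in place of the methyl of 3-methylphenyl.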